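The compounds below may be only part of what the source reports. "The series", "measured", "known", "first", "only" and "open" are said of these compounds alone.

For the measured compounds named here, compound 3 `CCNC(=O)Nc1ccc(S(=O)(=O)Oc2ccccc2C(C)C)cc1` gives 1100 nM in a functional assay on HT-29 cells (Homo sapiens) for antiproliferative activity, read by sulforhodamine B assay, with a stated time of 48 h (a lower number here means a stronger inhibitor, a higher number a weaker inhibitor), the lowest number of the three measured so far. Going by the values given here, compound 1 `CCC(=O)Nc1ccc(S(=O)(=O)Oc2ccccc2I)cc1` gives 11000 nM in this assay, and compound 2 `CC(C)C(=O)Nc1ccc(S(=O)(=O)Oc2ccccc2I)cc1` gives 13000 nM; the only measured step, a 1.2-fold higher number from compound 1 to compound 2 (0.07 log units; within the scatter), concerns the saturated chain on the amide and lies within the scatter.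

Compound 4 `CCNC(=O)Nc1ccc(S(=O)(=O)Oc2ccccc2I)cc1` differs from compound 3 by iodo in place of isopropyl on an aromatic carbon, on an aromatic carbon of a six-membered aromatic ring of carbon only, ortho to a large group. Among the compounds with values here, no measured step isolates this change: compound 1 and compound 2 carry the iodo group but also an amide instead of the ethylurea of compound 3, so their gap to compound 3 cannot be assigned to the aromatic substituent alone. Since compound 1 and compound 2 both sit far weaker than compound 3, a step toward a higher number is expected for compound 4, of the size a 3.6-fold higher number from compound 3 to compound 4 (0.56 log units; beyond the scatter), with wide uncertainty. Compound 4 is estimated at 4000 nM, within 1200 nM to 13000 nM.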

Compound 4, half-maximal inhibitory concentration: 5300 nM
Compound 4: middle estimate off by 1.3-fold (0.12 log units), on the low side; the range from low to high includes it.
By their numbers in this assay, from the lowest: compound 3; then compound 4; then compounds 1 and 2 (each within the scatter of the next).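

In this assay, the aromatic carbon now has a measured step of its own: with the ethylurea held constant, there is a 4.8-fold higher number from compound 3 to compound 4 (0.68 log units; beyond the scatter) for iodo in place of isopropyl, so isopropyl carries the lower number in this pair. With iodo held constant, the carbonyl substituent also gives its first steps beyond the scatter, with a 2.5-fold lower number from compound 2 to compound 4 (0.39 log units; beyond the scatter) for ethylamino in place of isopropyl and a 2.1-fold lower number from compound 1 to compound 4 (0.32 log units; beyond the scatter) for ethylamino in place of ethyl, so ethylamino carries the lower number in both pairs. No measured evidence bears on the reason for either change.

On these data alone, how a methyl, a chloro or a tert-butyl group on the same aromatic carbon would compare with iodo and isopropyl remains open. So does the effect of a longer chain or a cyclohexyl group on the urea nitrogen in place of ethyl.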